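Isobutyl Added Beside the Ring Nitrogen in Two Sulfonamides

This account rests on a few compounds, and the source may have more. Where it says the series, first, only, none or still open, it means among the compounds named here.

Measured so far:
compound 1 `Cc1ccc(S(=O)(=O)N2CCC(Cl)CC2)cc1` gives > 100000 nM in a functional assay on WiDr cells (Homo sapiens) for antiproliferative activity, read by sulforhodamine B assay, with a stated time of 48 h; on this read-out higher numbers stand for weaker inhibition of growth and lower numbers for stronger inhibition of growth;
compound 2 `Cc1ccc(S(=O)(=O)N2CC[C@@H](Cl)C[C@@H]2CC(C)C)cc1` gives 22000 nM;
compound 3 `Cc1ccc(S(=O)(=O)N2CC=C(Br)CC2)cc1` gives > 100000 nM.

The value of compound 1 is a limit of this assay, not a number. The value of compound 3 is likewise a limit. Two of the three measured compounds therefore sit at the limit of > 100000 nM in this assay, at which 2 of the 3 values shown sit.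

Compound 1 and compound 2 differ by one change, (isobutyl in place of hydrogen on a saturated ring carbon), and this change brings an at least 4.5-fold lower number from compound 1 to compound 2 (0.65 log units; beyond the scatter). Compound 4 `Cc1ccc(S(=O)(=O)N2CCC(Br)=CC2CC(C)C)cc1` has not yet been measured; it is related to compound 3 by isobutyl in place of hydrogen on a saturated ring carbon. The two cores differ, but that difference is not broken down here. Around the place of the change, compound 2 has the change two ring bonds from the ring atom that bears a chloro group, whereas compound 4 has it two ring bonds from the ring atom that bears a bromo group; so it is the same kind of change, not the same.

For compound 4 the expected step is an at least 3.3-fold lower number from compound 3 to compound 4 (0.52 log units; beyond the scatter), and this expectation rests on an at least 4.5-fold lower number from compound 1 to compound 2 (0.65 log units; beyond the scatter). Compound 4 is expected to give 30000 nM, estimated to lie between 10000 nM and 100000 nM.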

Compound 4, concentration for 50% growth inhibition: 16000 nM
Compound 4: middle estimate off by 1.9-fold (0.27 log units), on the high side, and the stated range covers the measured number.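

In this assay, isobutyl in place of hydrogen on a saturated ring carbon brings an at least 6.2-fold lower number from compound 3 to compound 4 (0.79 log units; beyond the scatter), so the change points the same way on both cores shown: the same change on two cores in this assay, an at least 4.5-fold lower number (0.65 log units; beyond the scatter) from compound 1 to compound 2 and an at least 6.2-fold lower number (0.79 log units; beyond the scatter) from compound 3 to compound 4; the limit leaves it open whether they differ

Compound 3 gives > 100000 nM, which is a limit and not a number. The full size of the step therefore remains unknown on this core, as it does on the core of compound 1, and the result shows agreement in direction across two cores only, not that the change brings a step of equal size or that it would carry to any further core: the limit of > 100000 nM in this assay, at which 2 of the 4 values shown sit.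

Among the compounds shown, isobutyl is the only group at this place, so it remains open whether methyl, a longer chain, benzyl or a chain bearing an amine would bring a similar step. From the compounds shown here alone, it also remains open whether the change would bring a lower number on a core with a fluoro group or a methoxy group in place of the chloro or bromo group.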